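The source may report more compounds than this note shows. Statements on the series, on what has been measured and on what is new or still open speak of the compounds shown alone.

Measured compounds in a functional assay for activation of Alpha-1A adrenergic receptor (Homo sapiens); a higher number here means that more compound is needed for the effect, a lower number that less compound is needed:
compound 1, `c1ccc(-c2ccno2)c(OCC2=NCCN2)c1`, gives 6.31 nM
compound 2, `c1ccc(-c2ccno2)c(OCc2c[nH]cn2)c1`, gives 158 nM
compound 3, `c1ccc(-c2cnco2)c(NCC2=NCCN2)c1`, gives 20 nM

Compound 1 and compound 2 share a core and differ in one place: a group of 5 heavy atoms (3 carbon, 2 nitrogen; one five-membered aromatic ring with 2 hetero atoms) in place of a group of 5 heavy atoms (3 carbon, 2 nitrogen; one five-membered non-aromatic ring with 2 hetero atoms), on a saturated chain carbon bound to an oxygen on an aromatic ring. This change produced a 25-fold higher number from compound 1 to compound 2 (1.40 log units; beyond the scatter) in this assay. Compound 3 carries a different core from compound 1, and the difference between the two cores is not broken down here; its value in this assay stands between those of compound 1 and compound 2.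

Compound 4, `c1ccc(-c2cnco2)c(NCc2c[nH]cn2)c1`, is not yet measured. It arises from compound 3 by a group of 5 heavy atoms (3 carbon, 2 nitrogen; one five-membered aromatic ring with 2 hetero atoms) in place of a group of 5 heavy atoms (3 carbon, 2 nitrogen; one five-membered non-aromatic ring with 2 hetero atoms), on a saturated chain carbon bound to a nitrogen on an aromatic ring. Within the data shown here, this is the same kind of change as the one from compound 1 to compound 2, though the place is not identical: in the first pair the saturated chain carbon is bound to an oxygen on an aromatic ring, in the second it is bound to a nitrogen on an aromatic ring. Because the same change gave a 25-fold higher number from compound 1 to compound 2 (1.40 log units; beyond the scatter), a step of similar size is expected for compound 4, namely a 23-fold higher number from compound 3 to compound 4 (1.35 log units; beyond the scatter). In this assay compound 4 is therefore estimated at 450 nM, most likely between 150 nM and 1500 nM.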

Compound 4, half-maximal effective concentration: 50.1 nM
The estimate for compound 4 lay 9.0-fold (0.95 log units) above the measured number, and the stated range ends above it.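

Exchanging the non-aromatic ring for 1H-imidazol-4-yl, on a saturated chain carbon bound to a nitrogen on an aromatic ring, gave a 2.5-fold higher number from compound 3 to compound 4 (0.40 log units; beyond the scatter) in this assay. The direction of the step held from one core to the other, but its size did not: the same change on two cores in this assay, a 25-fold higher number (1.40 log units; beyond the scatter) from compound 1 to compound 2 and a 2.5-fold higher number (0.40 log units; beyond the scatter) from compound 3 to compound 4, 10-fold (1.00 log units) apart, beyond the scatter of two such steps

In these two pairs, then, the change raises the number each time, yet a step read on one core does not give its size on the other; two pairs cannot show which part of the difference between the cores governs that size, nor whether the same holds on any further core.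

No pair shown separates the oxygen or nitrogen bound to the aromatic ring from the remaining difference between the two cores, and that question stays open. Also open, on these data alone, is how an amine or a longer chain carrying the 1H-imidazol-4-yl group would behave in this assay on either core.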